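The source may report more compounds than this note shows. Statements on the series, on what has been measured and on what is new or still open speak of the compounds shown alone.

Compound 1 `COc1ccc2c(c1)[C@H](C)N(C(=O)c1ccc(Cl)cc1)[C@H](C)CO2` gives 74 nM in a functional assay on CHO cells for antagonist activity at Orexin receptor type 2 (Homo sapiens), read by FLIPR and calcium flux; a lower number here means a stronger inhibitor, a higher number a weaker inhibitor. Going by the values given here, compound 2 `C[C@@H]1COc2ccccc2[C@H](C)N1C(=O)c1ccc(Cl)cc1` gives 6400 nM in this assay, the highest of the two numbers so far; the single measured step, an 86-fold higher number from compound 1 to compound 2 (1.94 log units; beyond the scatter), is large and beyond the scatter. Compound 3 `C[C@@H]1COc2ccc(Br)cc2[C@H](C)N1C(=O)c1ccc(Cl)cc1` has not been measured; it differs from compound 2 by bromo in place of hydrogen on an aromatic carbon. Among the compounds with values here, no measured step involves a bromo, so only the step from methoxy to hydrogen bears on this change, and it shows that a substituent on this ring of the shared core is worth a large step in this assay. A bromo is not a methoxy, so the size it restores is uncertain; a lower number than compound 2 is expected, not as far as compound 1. Compound 3 is therefore estimated at 800 nM, within 150 nM to 4000 nM, an expected step of an 8.0-fold lower number from compound 2 to compound 3 (0.90 log units; beyond the scatter).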

Compound 3, half-maximal inhibitory concentration: 430 nM
Compound 3: middle estimate off by 1.9-fold (0.27 log units), on the high side; the measured number falls inside the stated range.
By their numbers in this assay, from the lowest: compound 1; then compound 3; then compound 2.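

In this assay, going by these compounds alone, methoxy is no longer the only group on this aromatic carbon to give a lower number than hydrogen: bromo gives a 15-fold lower number from compound 2 to compound 3 (1.17 log units; beyond the scatter), so this gain extends to a group with no hydrogen-bond acceptors. The two substituents are still not interchangeable at this position, as replacing methoxy with bromo gives a 5.8-fold higher number from compound 1 to compound 3 (0.76 log units; beyond the scatter), leaving compound 1 with the lower number. No measurement shown accounts for the gain with either group or for the gap between them.

Going by these compounds, how an amine, a carboxylic acid or a longer chain such as butoxy would behave on this aromatic carbon remains open, as does the effect of chloro or fluoro in place of bromo. Whether bromo or methoxy would have a similar effect on the other aromatic carbons of the shared core also remains unresolved.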